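The source may report more compounds than this note shows. Statements on the series, on what has been measured and on what is new or still open speak of the compounds shown alone.

Compound 1 `Cc1cc(Nc2cc(-c3ccccc3)[nH]n2)n2nc(SCc3cccc(Br)c3)nc2n1`: 4820 nM
Compound 2 `Cc1cc(Nc2cc(-c3ccc(F)cc3)[nH]n2)n2nc(SCc3ccc(Br)cc3)nc2n1`: 2210 nM

In a functional assay on MGC-803 cells (Homo sapiens) for inhibition, read by MTT assay, with a stated time of 72 h (a higher number here means a weaker inhibitor, a lower number a stronger inhibitor), compound 1 gives 4820 nM, the higher of the two numbers, while compound 2 gives 2210 nM, a gap beyond the usual scatter. Compound 3 `Cc1cc(Nc2cc(-c3ccccc3)[nH]n2)n2nc(SCC3CC3)nc2n1` has not yet been measured. It differs from compound 1 in one place: cyclopropyl in place of 3-bromophenyl on a saturated chain carbon bound to a sulfur. Among the measured compounds shown here, no measured pair shows this change, so its effect is not known from these data. Compound 3 is expected to give a somewhat higher number than compound 1, an estimated step of a 1.9-fold higher number from compound 1 to compound 3 (0.27 log units; within the scatter). In this assay the value of compound 3 is estimated at 9000 nM, within a range from 3000 nM to 30000 nM.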

Compound 3, half-maximal inhibitory concentration: 16100 nM
The estimate for compound 3 lay 1.8-fold (0.25 log units) below the measured number; the measured number falls inside the stated range.
By their numbers in this assay, from the lowest: compound 2; then compound 1; then compound 3.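

In this assay, cyclopropyl in place of 3-bromophenyl on a saturated chain carbon bound to a sulfur gives a 3.3-fold higher number from compound 1 to compound 3 (0.52 log units; beyond the scatter) as the first one-place step read at this position. It shows that the group carried there changes the number, and that cyclopropyl does not stand in for 3-bromophenyl without loss. Nothing at hand explains the step. Whether the bromine or the phenyl ring accounts for it stays open. So does how an amine or a longer alkyl chain would read at this place.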